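The source may hold more compounds than are shown below. What is called first, only, known or untested is meant among the compounds shown, and "the series" means these compounds.

Three compounds of the series have a number in an ADME assay on L6 cells (Rattus norvegicus) for cytotoxicity, read by resazurin assay, with a stated time of 70 h; a lower number here means a stronger inhibitor, a higher number a weaker inhibitor. Compound 1 `N=C(N)c1ccc2oc(-c3ccc(OCCCOc4ccccc4)cc3)cc2c1` gives 7300 nM; compound 2 `CC(C)NC(=N)c1ccc2oc(-c3ccc(OCCCOc4ccccc4)cc3)cc2c1` gives 45600 nM; compound 3 `N=C(N)c1ccc2oc(-c3ccc(OCCCCOc4ccccc4)cc3)cc2c1` gives 1300 nM. Compound 3 holds the lowest number of the three, with compound 1 nearest and compound 2 furthest away. Compound 4 `CC(C)NC(=N)c1ccc2oc(-c3ccc(OCCCCOc4ccccc4)cc3)cc2c1` differs from compound 3 by isopropyl in place of hydrogen on an amine nitrogen. The same change has been measured once, as a 6.2-fold higher number from compound 1 to compound 2 (0.80 log units; beyond the scatter), a modest rise beyond the scatter. Compound 3 itself stands a step from compound 1, a 5.6-fold lower number from compound 1 to compound 3 (0.75 log units; beyond the scatter), so the chain change and the nitrogen change have each been seen singly but not together. Carrying the nitrogen step over, the step from compound 3 to compound 4 in this assay is expected as a 6.2-fold higher number from compound 3 to compound 4 (0.79 log units; beyond the scatter). Compound 4 is therefore estimated at 8000 nM, within a range from 3000 nM to 22000 nM.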

Compound 4, half-maximal inhibitory concentration: 6900 nM
For compound 4 the middle estimate is 1.2-fold (0.06 log units) above the measured one, and the stated range covers the measured number.
By their numbers in this assay, from the lowest: compound 3; then compounds 4 and 1 (each within the scatter of the next); then compound 2.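

In this assay, isopropyl in place of hydrogen on the amine nitrogen also raises the number when phenoxymethyl replaces phenoxy on the chain, a 5.3-fold higher number from compound 3 to compound 4 (0.72 log units; beyond the scatter), so the nitrogen step carries over between the two cores: the same change on two cores in this assay, a 6.2-fold higher number (0.80 log units; beyond the scatter) from compound 1 to compound 2 and a 5.3-fold higher number (0.72 log units; beyond the scatter) from compound 3 to compound 4, 1.2-fold (0.07 log units) apart, within the scatter of two such steps The chain change likewise holds with isopropyl present, a 6.6-fold lower number from compound 2 to compound 4 (0.82 log units; beyond the scatter): the same change on two cores in this assay, a 5.6-fold lower number (0.75 log units; beyond the scatter) from compound 1 to compound 3 and a 6.6-fold lower number (0.82 log units; beyond the scatter) from compound 2 to compound 4, 1.2-fold (0.07 log units) apart, within the scatter of two such steps Across these four compounds, the two changes therefore act independently of each other.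

Open, from the compounds shown here alone, is whether ethyl or cyclopentyl on the amine nitrogen gives a step of similar size. Also open, going by these compounds, is whether a longer chain than that of compound 3 lowers the number further.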